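Chain end ester in place of alcohol on an isoflavone ether

The source may report more compounds than this note shows. Statements on the series, on what has been measured and on what is new or still open speak of the compounds shown alone.

Measured so far:
compound 1, `CCCCC(Oc1ccc2c(=O)c(-c3ccc(O)cc3)coc2c1)C(=O)OCC`, 4500 nM;
compound 2, `CCCCCCC(Oc1ccc2c(=O)c(-c3ccc(O)cc3)coc2c1)C(=O)O`, 2000 nM;
compound 3, `O=c1c(-c2ccc(O)cc2)coc2cc(OCCCCCCO)ccc12`, 120 nM.

In an assay (Cricetulus griseus) for inhibition of aldehyde dehydrogenase, mitochondrial (Homo sapiens) (on this read-out higher numbers stand for weaker inhibition and lower numbers for stronger inhibition), compound 3 gives the lowest of the three numbers. Its nearest neighbour, compound 2, sits well above it, beyond the scatter, and compound 1 lies further still. Compound 4, `CCOC(=O)CCCCCOc1ccc2c(=O)c(-c3ccc(O)cc3)coc2c1`, has not yet been tested. Its structure differs from compound 3 in one place: ethoxycarbonyl in place of hydroxymethyl on a saturated chain carbon, five bonds along the chain from an oxygen on an aromatic ring. Compound 1 also carries an ethoxycarbonyl and gives a high number in this assay, though its branched chain keeps that pair from being a clean comparison. On this basis compound 4 is expected to lose some ground against compound 3, with the estimated step of a 6.7-fold higher number from compound 3 to compound 4 (0.82 log units; beyond the scatter) read as a weakening beyond the scatter. The value for compound 4 is estimated at 800 nM, within a range from 200 nM to 3000 nM.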

Compound 4, half-maximal inhibitory concentration: 280 nM
Beside the measured number, compound 4's estimate is 2.9-fold (0.46 log units) above it; the measured number falls inside the stated range.
By their numbers in this assay, from the lowest: compound 3; then compound 4; then compound 2; then compound 1.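

In this assay, among these compounds, the change at the chain end gives a 2.3-fold higher number from compound 3 to compound 4 (0.37 log units; beyond the scatter), the first step here between compounds that differ in one place. It shows that ethoxycarbonyl in place of hydroxymethyl on a saturated chain carbon, five bonds along the chain from an oxygen on an aromatic ring, costs a modest amount of inhibition, a loss beyond the scatter but far from an abolition of it. Nothing available accounts for the size of this step.

The compounds shown leave open how a carboxylic acid or a primary amine at this chain end would compare with the hydroxymethyl of compound 3 and the ethoxycarbonyl of compound 4. They also leave open whether the same exchange would give a step of similar size on a longer chain.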